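Swapping a dimethylamino tail for a methylpyrrolidinyl ring

A few compounds are considered here, and "the series" means these few. Any claim that something is new, unique, unknown or untested is made for them only; others in the source may bear on it.

Measured compounds:
compound 1, `CN(C)CCn1nc(Cc2ccc(Cl)cc2)c2ccccc2c1=O`: 200 nM
compound 2, `CN1CCC[C@@H]1Cn1nc(Cc2ccc(C(C)(C)C)cc2)c2ccccc2c1=O`: > 1990 nM

Among the compounds with values here, compound 1, with the structure `CN(C)CCn1nc(Cc2ccc(Cl)cc2)c2ccccc2c1=O`, is the only compound here with a numbered result in an assay for binding affinity to Alpha-1B adrenergic receptor (Homo sapiens) (a higher number here means a weaker inhibitor, a lower number a stronger inhibitor), where compound 1 gives 200 nM. Compound 2, with the structure `CN1CCC[C@@H]1Cn1nc(Cc2ccc(C(C)(C)C)cc2)c2ccccc2c1=O`, gives only a limit of the assay, > 1990 nM. That reading is the limit of > 1990 nM in this assay, at which 1 of the 2 values shown sits. Within the data shown here, compound 1 and compound 2 differ in two places at once, so their values show only that one is a number and the other a limit.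

Compound 3, with the structure `CN1CCCC1CCn1nc(Cc2ccc(Cl)cc2)c2ccccc2c1=O`, is not yet measured. It differs from compound 1 by 1-methylpyrrolidin-2-yl in place of dimethylamino on a saturated chain carbon, two bonds along the chain from an aromatic nitrogen. Among the measured compounds shown here, no measured pair isolates this exchange, so the expectation rests on compound 1 alone. The step from compound 1 to compound 3 is expected to be a 2.0-fold higher number from compound 1 to compound 3 (0.30 log units; within the scatter), a modest weakening that may not exceed the usual scatter. Compound 3 is therefore estimated at 400 nM, with a plausible range from 120 nM to 1500 nM.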

Compound 3, inhibition constant: 316 nM
For compound 3 the middle estimate is 1.3-fold (0.10 log units) above the measured one, within the range that was stated.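

In this assay, putting 1-methylpyrrolidin-2-yl in place of dimethylamino on a saturated chain carbon, two bonds along the chain from an aromatic nitrogen, gives a 1.6-fold higher number from compound 1 to compound 3 (0.20 log units; within the scatter). Within the data shown here, this is the first comparison here that isolates a single change at this position, with the rest of the molecule kept the same. The open dimethylamino group and the five-membered ring cannot be told apart in this assay, and nothing shown here gives a cause for that result.

From the compounds shown here alone, it remains open whether other amine groups at this position, such as a piperidine or a morpholine ring, would also give values within the scatter of compound 1. A carboxylic acid in place of the amine, or a longer chain, is also untested among the compounds shown.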